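The source may report more compounds than this note shows. Statements on the series, on what has been measured and on what is new or still open speak of the compounds shown alone.

The compounds share one core, which is seen in compound 1, `CC(C)CCC(=O)N[C@@H](C(=O)N1CCC(c2ccc(Cl)cc2)CC1)C(C)C`. Binding was measured in an assay on THP-1 cells for displacement of a labelled ligand from C-C chemokine receptor type 1 (Homo sapiens); on this read-out higher numbers stand for weaker inhibition and lower numbers for stronger inhibition. In this assay compound 1 gives 26 nM, the lowest of the three numbers recorded. Compound 2, `O=C(N[C@@H](C(=O)N1CCC(c2ccc(Cl)cc2)CC1)C1CCCCC1)c1ccccc1`, gives 121 nM in this assay, and compound 3, `CC(C)C(NC(=O)c1ccccc1)C(=O)N1CCN(c2ccc(Cl)c(Cl)c2)CC1`, gives 375 nM in this assay; each of these two numbers lies beyond the usual scatter from the number of compound 1. Compound 4, `CC(C)[C@@H](NC(=O)CCc1ccc(F)cc1)C(=O)N1CCC(c2ccc(Cl)cc2)CC1`, has not yet been measured. It differs from compound 1 in a single place: 4-fluorophenyl in place of isopropyl on a saturated chain carbon, two bonds along the chain from a carbonyl carbon. Within the data shown here, no step between two measured compounds that differ in only one place is available here, so nothing in the measured set calibrates this particular change, and the expectation rests on compound 1 alone. The step is expected to be small, with a modest gain in binding as the more probable direction, and it could well stay within the scatter. Compound 4 is expected to give 15 nM in this assay, with a range from 4 nM to 60 nM. That estimate corresponds to an expected step of a 1.7-fold lower number from compound 1 to compound 4 (0.24 log units; within the scatter).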

Compound 4, half-maximal inhibitory concentration: 70 nM
For compound 4 the middle estimate is 4.7-fold (0.67 log units) below the measured one; the measured number lies above the stated range.
By their numbers in this assay, from the lowest: compound 1; then compounds 4 and 2 (each within the scatter of the next); then compound 3.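

In this assay, among these compounds, 4-fluorophenyl in place of isopropyl gives a 2.7-fold higher number from compound 1 to compound 4 (0.43 log units; beyond the scatter), the only step here that isolates a change at a single place. At this saturated chain carbon, two bonds along the chain from a carbonyl carbon, a group of 7 heavy atoms with an aromatic ring therefore replaces one of 3 heavy atoms with no ring, and the result is a modest loss of binding rather than a gain. Nothing available accounts for this loss.

The compounds shown leave open whether the ring or its fluorine matters more at this position, a question that a plain phenyl group would help to settle. They also leave open how an amine or a carboxylic acid at the same place would read.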